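Aryl amine variation on the shared core, cell inhibition

The source may hold more compounds than are shown below. What is called first, only, known or untested is meant among the compounds shown, and "the series" means these compounds.

Compound 3 `Cc1n[nH]c2ccc(-c3nc4cnc(N5CCN(C)CC5)cn4c3Nc3ccc(Cl)cc3F)cc12` gives 0% in a functional assay on MV4-11 cells (Homo sapiens) for inhibition, with a stated time of 120 h, tested at 10 uM; a higher number here means more inhibition at the concentration tested (going by the name of the read-out), a lower number less inhibition. Compound 2 `Cc1n[nH]c2ccc(-c3nc4cnc(N5CCN(C)CC5)cn4c3Nc3ccccc3)cc12` gives 0%, and the two stand level, together the lowest of the three numbers shown; the step of no change at the digits printed from compound 2 to compound 3 (within the scatter) lies within the scatter. Compound 1 `Cc1n[nH]c2ccc(-c3nc4cnc(N5CCN(C)CC5)cn4c3Nc3cccc(F)c3)cc12` gives 18.5%, and the steps of a number 18.5 percentage points lower from compound 1 to compound 2 (beyond the scatter) and a number 18.5 percentage points lower from compound 1 to compound 3 (beyond the scatter) are beyond the scatter but modest. Compound 4 `COc1ccc(Nc2c(-c3ccc4[nH]nc(C)c4c3)nc3cnc(N4CCN(C)CC4)cn23)cc1OC` differs from compound 3 by 3,4-dimethoxyphenyl in place of 4-chloro-2-fluorophenyl on a nitrogen on an aromatic ring. Both measured changes of this aryl group moved the read-out only modestly or not at all, and none of them introduced methoxy groups, so the expected step of a number 5 percentage points higher from compound 3 to compound 4 (within the scatter) from compound 3 to compound 4 is small and may not exceed the scatter. Compound 4 is therefore estimated at 5%, within a range of 0% to 25%.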

Compound 4, a percentage reported as inhibition, at one concentration (the size of the read-out at that concentration, not a potency): 6.27%
Compound 4: the middle estimate sits 1.3 percentage points below what was measured, and the stated range covers the measured number.
By their numbers in this assay, from the lowest: compounds 2, 3 and 4 (each within the scatter of the next); then compound 1.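

With 3,4-dimethoxyphenyl on a nitrogen on an aromatic ring, methoxy groups enter this position for the first time among the compounds shown, yet in this assay the steps of a number 6.3 percentage points higher from compound 3 to compound 4 (within the scatter) and a number 6.3 percentage points higher from compound 2 to compound 4 (within the scatter) stay within the scatter. Within the data shown here, only the step of a number 12.2 percentage points lower from compound 1 to compound 4 (beyond the scatter) passes beyond it, and it is modest, so compound 1 with its 3-fluorophenyl remains apart from the other three. No supporting data bear on what lies behind these differences.

Open, on these data alone, is whether a single methoxy group on this aryl ring behaves like the pair in compound 4. Also open, as far as these compounds go, is how an aminomethyl or carboxylic acid group on this ring would read out in this assay on the shared core.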